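A few compounds are considered here, and "the series" means these few. Any claim that something is new, unique, unknown or untested is made for them only; others in the source may bear on it.

Three compounds have been measured so far in a functional assay on DU-145 cells (Homo sapiens) for inhibition, read by sulforhodamine B assay, with a stated time of 48 h (a higher number here means a weaker inhibitor of growth, a lower number a stronger inhibitor of growth), and give these results:

- Compound 1 `COc1ccc(C(=O)C2=CCCCc3c2cc(OC)c(OC)c3OC)c(O)c1O` gives > 10000 nM 
- Compound 2 `COc1ccc(C(=O)C2=CCCc3c2cc(OC)c(OC)c3OC)c(O)c1O` gives 3400 nM 
- Compound 3 `COc1ccc2c(c1O)CCCC(c1cc(OC)c(OC)c(OC)c1)=C2` gives 440 nM 

The result for compound 1 (> 10000 nM) is a limit and not a number. Of the two actual numbers, compound 2 has the higher (3400 nM), and its gap to compound 3 lies beyond the scatter.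

Compound 4 `COc1ccc(C(=O)C2=CCCc3c2cc(OC)c(OC)c3OC)cc1O` has hydrogen in place of hydroxy on an aromatic carbon, ortho to a hydroxy group and a large group and meta to a methoxy group (hydrogen in place of hydroxy on an aromatic carbon). Among the measured compounds shown here, no measured pair shows this change, so only a loose expectation is possible in this assay: a modest move to a lower number. The expected change is a 2.3-fold lower number from compound 2 to compound 4 (0.36 log units; beyond the scatter) and may prove to lie within the scatter. For compound 4 the estimated value is 1500 nM, with an expected range from 250 nM to 9000 nM (estimates only).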

Compound 4, concentration for 50% growth inhibition: 3100 nM
For compound 4 the middle estimate is 2.1-fold (0.32 log units) below the measured one; the range from low to high includes it.
By their numbers in this assay, from the lowest: compound 3; then compounds 4 and 2 (each within the scatter of the next). At a limit, above all of these: compound 1.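

In this assay, the step at this position, on an aromatic carbon ortho to a hydroxy group and a large group and meta to a methoxy group, is a 1.1-fold lower number from compound 2 to compound 4 (0.04 log units; within the scatter). Among the compounds shown here, this is the first reading of this position, and it shows that hydroxy and hydrogen there cannot be told apart in this assay. Nothing measured here offers an explanation of this result.

The compounds shown leave open whether an amine or a fluorine on this carbon would read differently. They also leave open whether the same exchange gives a similar step on the core of compound 1.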